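This account rests on a few compounds, and the source may have more. Where it says the series, first, only, none or still open, it means among the compounds named here.

Working notes on the series in a functional assay on HCT-116 cells (Homo sapiens) for cytotoxicity, read by MTT assay, with a stated time of 48 h; on this read-out higher numbers stand for weaker inhibition and lower numbers for stronger inhibition. Compound 1 `O=C(Nc1ccc(Cl)cc1)c1cn(-c2ccccc2)nc1-c1ccc(Cl)cc1` gives 2990 nM in this assay. Compound 2 `O=C(Nc1ccc(Br)cc1)c1cn(-c2ccccc2)nc1-c1ccc(Cl)cc1` carries bromo in place of chloro on an aromatic carbon and gives 4360 nM in this assay; the step of a 1.5-fold higher number from compound 1 to compound 2 (0.16 log units; within the scatter) is within the scatter. Among the compounds with values here, compound 2 thus holds the highest of the two numbers so far, with compound 1 nearest and not separable from it. Compound 3 `COc1ccc(NC(=O)c2cn(-c3ccccc3)nc2-c2ccc(Cl)cc2)cc1` is not yet measured. Its change from compound 2 is methoxy in place of bromo on an aromatic carbon. Within the data shown here, the only measured step at this place, a 1.5-fold higher number from compound 1 to compound 2 (0.16 log units; within the scatter), exchanged one halogen for another and stayed within the scatter; no measured pair exchanges a halogen for methoxy, so the direction of this change is uncovered. The expected step of a 1.1-fold lower number from compound 2 to compound 3 (0.04 log units; within the scatter) is therefore set near none beyond the scatter, with a wide range. Compound 3 is expected at 4000 nM, between 1500 nM and 12000 nM.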

Compound 3, half-maximal inhibitory concentration: 1330 nM
Estimate against measurement, compound 3: 3.0-fold (0.48 log units) above; the whole stated range lies above it.
By their numbers in this assay, from the lowest: compound 3; then compounds 1 and 2 (each within the scatter of the next).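

At this position, methoxy separates from the halogens in this assay, whereas the exchange of chloro for bromo gave no separable change. Both a 3.3-fold lower number from compound 2 to compound 3 (0.52 log units; beyond the scatter) and a 2.2-fold lower number from compound 1 to compound 3 (0.35 log units; beyond the scatter) are beyond the scatter and point the same way, leaving compound 3 with the lowest number of the three, though both steps are modest. No measurement available here bears on what lies behind this separation. The compounds shown leave open whether a methyl, a hydroxyl or an amine at this place would group with methoxy or with the halogens, and whether a longer ether such as ethoxy would keep the lower number. They also leave open whether methoxy in place of chloro on the other chlorine-bearing aromatic ring of the core would give a step of similar size.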